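Butyl to 4-methoxyphenyl on the sulfonyl sulfur

The source may report more compounds than this note shows. Statements on the series, on what has been measured and on what is new or still open speak of the compounds shown alone.

Compound 1 `CCCCS(=O)(=O)N1CCC2(CC1)OOC1(CCCC1)OO2` is the starting point for this step in a functional assay on Huh-7 cells (Homo sapiens) for cytotoxicity, read by MTT assay, with a stated time of 72 h; a higher number here means that more compound is tolerated, a lower number that less compound is tolerated. Compound 1 gives > 100 ug/mL, which is a limit and not a number. Compound 2 `CCCCS(=O)(=O)N1CCC2(CC1)OOC1(CCCCCC1)OO2` gives > 100 ug/mL, which is also a limit. The two measured compounds therefore share one position: the limit of > 100 ug/mL in this assay, at which 2 of the 2 values shown sit. Neither result gives a numerical cytotoxic concentration, so compound 1 can be placed only at this limit.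

Compound 3 `COc1ccc(S(=O)(=O)N2CCC3(CC2)OOC2(CCCC2)OO3)cc1` keeps the core of compound 1 and carries 4-methoxyphenyl in place of butyl on a sulfonyl sulfur. Going by the values given here, no measured pair tests a change at this place, so the expectation is weakly supported. The expected change in this assay, a number no higher from compound 1 to compound 3 (the limit leaves the size open), is none beyond the usual scatter, with no direction foreseen. This expectation rests on the limit reached by compound 1, > 100 ug/mL. A further reading reported only as a limit is considered the likeliest outcome. For compound 3 the estimated half-maximal cytotoxic concentration is 100 ug/mL, with an expected range of 40 ug/mL to 250 ug/mL.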

Compound 3, half-maximal cytotoxic concentration: > 100 ug/mL
Compound 3 ended at the assay's limit (the forecaster's own chance of this, stated with the estimate: 70%); the middle value lies on the limit itself.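

Compound 1 and compound 3 both end at a limit in this assay, so no step can be read for 4-methoxyphenyl in place of butyl on the sulfonyl sulfur: the limit of > 100 ug/mL in this assay, at which 3 of the 3 values shown sit.

The compounds shown leave open at what concentration any of them becomes cytotoxic, and whether butyl and 4-methoxyphenyl differ at all in this read-out.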